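Ethylaminopyridine aryl ureas: cytotoxicity series notes

A few compounds are considered here, and "the series" means these few. Any claim that something is new, unique, unknown or untested is made for them only; others in the source may bear on it.

Measured so far:
compound 1, `CCNc1cc(-c2ccc(NC(=O)Nc3c(C)cccc3C)cc2C(F)(F)F)ccn1`, 22000 nM
compound 2, `CCNc1cc(-c2ccc(NC(=O)Nc3c(C)cccc3C)cc2OC)ccn1`, > 30000 nM
compound 3, `CCNc1cc(-c2ccc(NC(=O)Nc3ccc(OC)cc3)cc2F)ccn1`, 19600 nM

In a functional assay on BT-483 cells (Homo sapiens) for cytotoxicity, read by MTT assay, with a stated time of 24 h (a higher number here means a weaker inhibitor, a lower number a stronger inhibitor), compound 1 gives 22000 nM. Compound 2 reaches only the limit of this assay, > 30000 nM, so its value is a limit and not a number. Compound 3 gives 19600 nM in this assay, the lowest of the two numbers, though compound 1 sits within the scatter of it. The change trifluoromethyl in place of methoxy on an aromatic carbon gives an at least 1.3-fold lower number from compound 2 to compound 1 (0.13 log units; that floor lies within the scatter); the size of that step is bounded by the limit of > 30000 nM in this assay, at which 1 of the 3 values shown sits. How the core of compound 3 differs from that of compound 2 is not broken down here.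

Compound 4, `CCNc1cc(-c2ccc(NC(=O)Nc3ccc(C(F)(F)F)cc3)cc2F)ccn1`, is not yet measured. It carries trifluoromethyl in place of methoxy on an aromatic carbon. This is the same kind of change as from compound 2 to compound 1, but the place differs: there it sat ortho to a 2-(ethylamino)pyridin-4-yl group and meta to a large group, here it sits para to a large group. Since the measured step rests on a limit, only a small step is expected from compound 3 to compound 4, a 1.3-fold lower number from compound 3 to compound 4 (0.12 log units; within the scatter), and compound 4 is expected to give about 15000 nM, between 6000 nM and 30000 nM.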

Compound 4, half-maximal inhibitory concentration: 26800 nM
The estimate for compound 4 lay 1.8-fold (0.25 log units) below the measured number; measured number inside the range.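

In this assay, for the compounds shown here, trifluoromethyl in place of methoxy, para to a large group, gives a 1.4-fold higher number from compound 3 to compound 4 (0.14 log units; within the scatter), so this pair shows no step that can be told from the scatter. Set beside the earlier step, the record for this change on two cores reads: the same change on two cores in this assay, an at least 1.3-fold lower number (0.13 log units; that floor lies within the scatter) from compound 2 to compound 1 and a 1.4-fold higher number (0.14 log units; within the scatter) from compound 3 to compound 4; the limit leaves it open whether they differ. The series therefore gives no evidence that the change carries a real shift from one core to the other, and it shows neither that the two cores respond alike nor that they respond differently, as one end of the comparison is not a number: the limit of > 30000 nM in this assay, at which 1 of the 4 values shown sits.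

The compounds shown leave open whether an amine, a carboxylic acid or a nitrile in the same place on the core of compound 3 would move the number beyond the scatter. They also leave open how large this change is on the core of compound 1 when both ends of the step are numbers rather than a limit.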